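Shortening the side chain of compound 3

The source may hold more compounds than are shown below. What is called first, only, known or untested is meant among the compounds shown, and "the series" means these compounds.

Three compounds sharing one core differ only in the chain on the amine attached to the aromatic ring. In an assay on isolated protein for inhibition of Amine oxidase [flavin-containing] A (Homo sapiens), read by fluorescence and Amplex Red, with a stated time of 30 min, tested at 0.1 uM (on this read-out lower numbers stand for a weaker effect and higher numbers for a stronger effect at the one concentration tested), compound 1 `CCCCNc1nnc(SCC(=O)N(Cc2cccc([N+](=O)[O-])c2)c2ccc(F)cc2)s1` gives 33.6%, compound 2 `CC(C)CNc1nnc(SCC(=O)N(Cc2cccc([N+](=O)[O-])c2)c2ccc(F)cc2)s1` gives 31.8%, and compound 3 `COCCNc1nnc(SCC(=O)N(Cc2cccc([N+](=O)[O-])c2)c2ccc(F)cc2)s1` gives 61.1%, the highest of the three. Both a number 27.5 percentage points higher from compound 1 to compound 3 (beyond the scatter) and a number 29.3 percentage points higher from compound 2 to compound 3 (beyond the scatter) rose beyond the scatter, whereas a number 1.8 percentage points lower from compound 1 to compound 2 (within the scatter). Compound 4 `CCNc1nnc(SCC(=O)N(Cc2cccc([N+](=O)[O-])c2)c2ccc(F)cc2)s1` is next: hydrogen in place of methoxy on a saturated chain carbon, two bonds along the chain from a nitrogen on an aromatic ring. A fall is expected in this assay because a number 27.5 percentage points higher from compound 1 to compound 3 (beyond the scatter) and a number 29.3 percentage points higher from compound 2 to compound 3 (beyond the scatter) were the only gains seen and both came with the methoxy that now leaves. The expected step is a number 26.1 percentage points lower from compound 3 to compound 4 (beyond the scatter). Compound 4 is therefore estimated at 35% in this assay, between 20% and 55%.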

Compound 4, a percentage reported as inhibition, at one concentration (the size of the read-out at that concentration, not a potency): 42.1%
Estimate against measurement, compound 4: 7.1 percentage points below; the range from low to high includes it.
By their numbers in this assay, from the lowest: compounds 2, 1 and 4 (each within the scatter of the next, the first and the last beyond it); then compound 3.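

In this assay the loss of the methoxy from the 2-methoxyethyl chain gives a number 19 percentage points lower from compound 3 to compound 4 (beyond the scatter) and leaves the ethylamino compound without the high reading of compound 3. Among the plain chains, methyl in place of isopropyl gives a number 10.3 percentage points higher from compound 2 to compound 4 (beyond the scatter) while hydrogen in place of ethyl gives a number 8.5 percentage points higher from compound 1 to compound 4 (within the scatter) so shortening alone brings only a small or unclear change. Nothing measured here explains why the methoxy matters. As far as these compounds go, whether a hydroxyl or an amine in place of the methoxy on the same chain would read like compound 3 stays open, and so does a longer chain that still carries the methoxy.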